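Benzyl ring change from compound 3 to compound 4

The source may hold more compounds than are shown below. What is called first, only, known or untested is meant among the compounds shown, and "the series" means these compounds.

compound 1 `CN1CCN(c2ccc(Nc3ncc(Cl)c(Nc4ccccc4)n3)nc2)CC1` gives 7990 nM
compound 2 `CN1CCN(c2ccc(Nc3ncc(Cl)c(NCc4ccc(C(F)(F)F)cc4)n3)nc2)CC1` gives 26200 nM
compound 3 `CN1CCN(c2ccc(Nc3ncc(Cl)c(NCc4ccc(F)cc4)n3)nc2)CC1` gives 39700 nM

In an ADME assay on L02 cells (Homo sapiens) for inhibition, read by CCK-8 assay, with a stated time of 48 h (on this read-out higher numbers stand for weaker inhibition of growth and lower numbers for stronger inhibition of growth), compound 3 stands level with compound 2, at a 1.5-fold higher number from compound 2 to compound 3 (0.18 log units; within the scatter). Compared with compound 1, the number is clearly higher, at a 5.0-fold higher number from compound 1 to compound 3 (0.70 log units; beyond the scatter), much as in a 3.3-fold higher number from compound 1 to compound 2 (0.52 log units; beyond the scatter).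

Compound 4 `COc1cccc(CNc2nc(Nc3ccc(N4CCN(C)CC4)cn3)ncc2Cl)c1` has 3-methoxyphenyl in place of 4-fluorophenyl on a saturated chain carbon bound to a nitrogen on an aromatic ring. The steps from compound 1 replace phenyl with a substituted benzyl group, which compound 4 keeps. Compound 2 and compound 3 differ only in the ring substituent, and that swap stayed within the scatter. Among the compounds with values here, no measured compound carries methoxy, so the expectation is weakly founded, and no step beyond the scatter is expected.

The estimated step is a 1.3-fold lower number from compound 3 to compound 4 (0.12 log units; within the scatter).

Compound 4 is expected at 30000 nM, within an estimated range of 14000 nM to 62000 nM.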

Compound 4, concentration for 50% growth inhibition: 16200 nM
Estimate against measurement, compound 4: 1.9-fold (0.27 log units) above; the measured number falls inside the stated range.
By their numbers in this assay, from the lowest: compound 1; then compounds 4, 2 and 3 (each within the scatter of the next, the first and the last beyond it).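

In this assay, within the data shown here, the ring on the saturated chain carbon bound to a nitrogen on an aromatic ring can move the read-out: 3-methoxyphenyl in place of 4-fluorophenyl gives a 2.5-fold lower number from compound 3 to compound 4 (0.39 log units; beyond the scatter) and is the first ring change among the benzyl compounds to pass the scatter, while 3-methoxyphenyl in place of 4-(trifluoromethyl)phenyl gives a 1.6-fold lower number from compound 2 to compound 4 (0.21 log units; within the scatter) and stays within it. The benzyl-for-phenyl change still leaves a 2.0-fold higher number from compound 1 to compound 4 (0.31 log units; beyond the scatter) in this series. Nothing measured here explains these steps.

The compounds shown do not separate the methoxy group from its place on the ring. Going by these compounds, how an amine or a carboxylic acid on this ring, or a longer chain to it, would read stays open.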